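The source may hold more compounds than are shown below. What is called first, only, known or untested is meant among the compounds shown, and "the series" means these compounds.

In a functional assay on MCF7 cells (Homo sapiens) for antiproliferative activity, read by sulforhodamine B assay, with a stated time of 72 h (a lower number here means a stronger inhibitor, a higher number a weaker inhibitor), compound 1 `O=C(Cn1nc(-c2ccccc2)c2ccccc2c1=O)Nc1ccccc1` gives 43000 nM and compound 2 `O=C(Cn1nc(-c2ccccc2)c2ccccc2c1=O)Nc1cccc(Cl)c1` gives 74000 nM. These two numbers lie within the usual scatter of each other, so compound 2 cannot be told apart from compound 1. Compound 3 `O=C(Cn1nc(-c2ccccc2)c2ccccc2c1=O)Nc1ccc(Cl)cc1` keeps the shared core, and the change is 4-chlorophenyl in place of 3-chlorophenyl on an amide-type nitrogen. Going by the values given here, the one measured step that bears on this, a 1.7-fold higher number from compound 1 to compound 2 (0.24 log units; within the scatter), put chloro in place of hydrogen on an aromatic carbon and stayed within the scatter. No step beyond the scatter is therefore expected in this assay. The expected step is a 1.3-fold lower number from compound 2 to compound 3 (0.13 log units; within the scatter). For compound 3 the estimated value is 55000 nM, with an expected range from 25000 nM to 120000 nM.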

Compound 3, half-maximal inhibitory concentration: 33000 nM
Compound 3: the middle estimate sits 1.7-fold (0.22 log units) above what was measured; the measured number falls inside the stated range.
By their numbers in this assay, from the lowest: compounds 3, 1 and 2 (each within the scatter of the next, the first and the last beyond it).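

Moving the chloro from 3-chlorophenyl to 4-chlorophenyl gives a 2.2-fold lower number from compound 2 to compound 3 (0.35 log units; beyond the scatter) in this assay and is the only modest step shown, so with the same atoms, where the chloro sits on this ring can matter. Against the unsubstituted compound, the chloro gives a 1.3-fold lower number from compound 1 to compound 3 (0.11 log units; within the scatter) and so does not separate the two. No measurement here explains the difference between the two chloro compounds. From the compounds shown here alone, whether an amine, a methoxy group or a carboxylic acid in place of the chloro would shift the number further remains open.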